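A few compounds are considered here, and "the series" means these few. Any claim that something is new, unique, unknown or untested is made for them only; others in the source may bear on it.

Compound 1: `COC(=O)c1sc2cc(-c3cccnc3)cnc2c1N`, > 112000 nM. Compound 2: `COC(=O)c1sc2cc(-c3ccc4c(ccn4C)c3)cnc2c1N`, 21200 nM.

The account follows a single change on the shared core. In a functional assay on A-375 cells (Homo sapiens) for inhibition, read by sulforhodamine B assay, with a stated time of 48 h (on this read-out lower numbers stand for stronger inhibition of growth and higher numbers for weaker inhibition of growth), compound 1 gives > 112000 nM, and this is a limit of the assay, not a measured number. Compound 1 therefore stands at the limit of > 112000 nM in this assay, at which 1 of the 2 values shown sits, so no number is known for it, only that it sits at the edge of what the assay can report. Compound 2, which carries a 1-methylindol-5-yl group in the same position, gives 21200 nM in this assay, and this is a real number.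

Compound 3 (`COC(=O)c1sc2cc(-c3ccc(N)cc3)cnc2c1N`) has not yet been measured. It differs from compound 1 by 4-aminophenyl in place of pyridin-3-yl on an aromatic carbon. Among the compounds with values here, no measured pair shows this exact change, so the expectation rests on compound 2 alone, whose value of 21200 nM shows that an aryl group other than pyridin-3-yl can bring a number within reach of this assay. The step of an at least 2.8-fold lower number from compound 1 to compound 3 (0.44 log units; beyond the scatter) is expected to go toward stronger inhibition of growth, beyond the usual scatter. Compound 3 is expected to give about 40000 nM in this assay, between 10000 nM and 112000 nM.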

Compound 3, concentration for 50% growth inhibition: 80800 nM
Compound 3: middle estimate off by 2.0-fold (0.31 log units), on the low side, and the stated range covers the measured number.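

In this assay compound 3 gives 80800 nM, so 4-aminophenyl, with its one six-membered aromatic ring of carbon only, also yields a real number at this position, although compound 2 at 21200 nM remains the lower of the two values. The change itself can be read only as an at least 1.3-fold lower number from compound 1 to compound 3 (0.14 log units; that floor lies within the scatter), so these data do not establish that 4-aminophenyl inhibits growth more strongly than pyridin-3-yl. The step remains a floor because compound 1 has no measured number, only a limit of the assay: the limit of > 112000 nM in this assay, at which 1 of the 3 values shown sits.

The compounds shown leave open whether the result comes from the amine or from the carbon-only ring, a question that plain phenyl, 4-hydroxyphenyl or 3-aminophenyl on the same aromatic carbon would help to separate. They also leave open how the rest of the shared core bears on growth inhibition, since the methyl ester stays the same throughout and a carboxylic acid or an amide in its place would test that part of the molecule.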